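Removing the Carboxy Group from Compound 2

This account rests on a few compounds, and the source may have more. Where it says the series, first, only, none or still open, it means among the compounds named here.

Measured so far in a functional assay on the whole organism with Rattus norvegicus as the target, with a stated time of 4 h, at a dose of 40 mg/kg by the intraperitoneal route; a lower number here means less inhibition, a higher number more inhibition at the dose given (going by the name of the read-out):
compound 1, `CCOCc1c(C)nc2c(OCc3ccccc3)cccn12`: 84%
compound 2, `Cc1nc2c(OCc3ccccc3)cccn2c1CC(=O)O`: 12%

Compound 2 stands at the lower of the two numbers. Against compound 1 it is set apart by a single change, and that change is matched by a large drop: a number 72 percentage points lower from compound 1 to compound 2 (beyond the scatter). The next compound, compound 3, `Cc1nc2c(OCc3ccccc3)cccn2c1C`, has not yet been measured in this assay. Its difference from compound 2 is hydrogen in place of carboxy on a saturated chain carbon bound to an aromatic carbon. The same carboxy group that enters in the step from compound 1 to compound 2 leaves here, so that one step is the only measured one that bears on the present question, and it was large. The group that remains behind is a hydrogen rather than the ethoxy of compound 1, so the earlier drop need not be undone in full. Still, the expectation is that compound 3 moves upward beyond the scatter, by a number 43 percentage points higher from compound 2 to compound 3 (beyond the scatter). Compound 3 is therefore estimated to give 55%, with a range from 25% to 85%.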

Compound 3, a percentage reported as inhibition, in the whole organism at one dose (the size of the read-out at that dose, not a potency): 99%
Compound 3: middle estimate off by 44 percentage points, on the low side; measured number above the stated range.
By their numbers in this assay, from the lowest: compound 2; then compound 1; then compound 3.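

The new result shows that, in this assay, this saturated chain carbon bound to an aromatic carbon needs no added group for a high reading: with only hydrogen in place of carboxy, the number is a number 87 percentage points higher from compound 2 to compound 3 (beyond the scatter). The low reading of compound 2 therefore goes with the carboxy group itself, and the change from carboxymethyl to methyl does more than cancel the earlier drop of a number 72 percentage points lower from compound 1 to compound 2 (beyond the scatter), since ethoxy is not needed either: the number is a number 15 percentage points higher from compound 1 to compound 3 (beyond the scatter), a modest step, and compound 3 now stands highest of the compounds shown. Nothing measured here explains either step.

With only ethoxy, carboxy and hydrogen compared at this place, the compounds shown leave open whether the loss belongs to the carboxylic acid alone or would also come with an amine, a hydroxy group or a methyl ester of the acid. They also leave open whether a longer alkyl chain would hold the high reading, and how any of these compounds would behave at other doses or times, as each number comes from a single dose.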